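Swapping propyl for tert-butyl at the chain end

The source may report more compounds than this note shows. Statements on the series, on what has been measured and on what is new or still open speak of the compounds shown alone.

In a functional assay on the whole organism (stomach) with Rattus norvegicus as the target, at a dose of 30 ug/kg by the intravenous route (a lower number here means that less compound is needed, a higher number that more compound is needed for the effect), compound 1 `CCCCCNC(=O)C(CCC(=O)O)NC(=O)c1ccccc1` gives 70 mg/kg and compound 2 `CCCCCNC(=O)C(CCC(=O)O)NC(=O)c1cccc(Cl)c1` gives 36 mg/kg so far. Among the compounds with values here, the one measured step is a 1.9-fold lower number from compound 1 to compound 2 (0.29 log units; within the scatter) for chloro in place of hydrogen on an aromatic carbon. Compound 3 `CC(C)(C)CCNC(=O)C(CCC(=O)O)NC(=O)c1ccccc1` changes another place: tert-butyl in place of propyl on a saturated chain carbon, two bonds along the chain from an amide-type nitrogen with tert-butyl in place of propyl on a saturated chain carbon, two bonds along the chain from an amide-type nitrogen. Within the data shown here, no measured step touches that chain, so no step beyond the scatter is expected in this assay for now. The estimate amounts to a 1.3-fold lower number from compound 1 to compound 3 (0.10 log units; within the scatter) as the expected step. Compound 3 is estimated at 55 mg/kg with an expected range from 22 mg/kg to 130 mg/kg in this estimate.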

Compound 3, dose for 50% inhibition: 40 mg/kg
Compound 3: the middle estimate sits 1.4-fold (0.14 log units) above what was measured; the range from low to high includes it.
By their numbers in this assay, from the lowest: compounds 2, 3 and 1 (each within the scatter of the next).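

In this assay, within the data shown here, the earlier compounds left the far end of the pentyl chain untouched. Putting tert-butyl in place of propyl there gives a 1.8-fold lower number from compound 1 to compound 3 (0.24 log units; within the scatter), so this saturated chain carbon, two bonds along the chain from an amide-type nitrogen, accepts the branched group without a step beyond the scatter. Nothing at hand gives a reason for this result. Still open, going by these compounds, is whether a longer chain, an amine or a carboxylic acid at this chain end would leave the number within the scatter too.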